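The source may report more compounds than this note shows. Statements on the series, on what has been measured and on what is new or still open speak of the compounds shown alone.

Working notes on the series. Compound 1 is `C/C(C(=O)NC1CC1)=C(/C)c1ccc(Br)cc1`, compound 2 is `C=CCNC(=O)/C(C)=C(\C)c1ccc(OC)cc1`, compound 3 is `C/C(C(=O)NC1CC1)=C(/C)c1ccc(C)cc1`, and the as yet unmeasured compound 4 is `COc1ccc(/C(C)=C(\C)C(=O)NC2CC2)cc1`. In a toxicity assay on the whole organism (strain Icem-CET (SPF Caw)) for cytotoxicity, with Mus musculus as the target (a lower number here means that less compound is needed, a higher number that more compound is needed for the effect), compound 1 gives 130 mg/kg. In this assay compound 2 gives 300 mg/kg. In this assay compound 3 gives 150 mg/kg, the second highest of the three numbers, nearest to compound 1 and furthest from compound 2, both gaps within the scatter. For the measured compounds named here, the only single-change step measured so far, a 1.2-fold higher number from compound 1 to compound 3 (0.06 log units; within the scatter), shows a swap on the aromatic carbon leaving the number within the scatter.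

Compound 4 differs from compound 3 by methoxy in place of methyl on an aromatic carbon. Going by the values given here, no measured step covers methoxy in place of methyl directly. Among the compounds with values here, compound 2 also carries a methoxy group but differs from compound 3 elsewhere as well, so no single-change step connects them; the values of compound 2 and compound 3 lie within the scatter of each other. Because compound 1 and compound 3 sit within the scatter across the aromatic swap a 1.2-fold higher number from compound 1 to compound 3 (0.06 log units; within the scatter), compound 4 is expected to show only a small shift, a 1.3-fold higher number from compound 3 to compound 4 (0.12 log units; within the scatter). Compound 4 is therefore estimated at 200 mg/kg in this assay, with a range from 100 mg/kg to 400 mg/kg.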

Compound 4, dose for half-maximal effect: 250 mg/kg
The estimate for compound 4 lay 1.3-fold (0.10 log units) below the measured number, within the range that was stated.
By their numbers in this assay, from the lowest: compounds 1, 3, 4 and 2 (each within the scatter of the next, the first and the last beyond it).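

In this assay, methoxy on this aromatic carbon, para to a large group, adds to the picture from the bromo-to-methyl swap: a 1.7-fold higher number from compound 3 to compound 4 (0.22 log units; within the scatter) and a 1.9-fold higher number from compound 1 to compound 4 (0.28 log units; within the scatter). With a 1.2-fold higher number from compound 1 to compound 3 (0.06 log units; within the scatter) alongside them, bromo, methyl and methoxy at this position, all with cyclopropyl on the amide-type nitrogen, stand within the scatter of one another, so the earlier result for one swap now holds for all three pairs among these groups. For the compounds shown here, compound 4 also gives the first single-change reading at the amide-type nitrogen, with methoxy held constant: a 1.2-fold lower number from compound 2 to compound 4 (0.08 log units; within the scatter), so cyclopropyl and allyl are not told apart here, and no supporting data bear on why these steps are this small.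

Open, from the compounds shown here alone, is whether an amine or a carboxylic acid on this aromatic carbon, or a longer chain on the amide-type nitrogen, would also stay within the scatter. Compound 2 is the only allyl compound shown, so whether the aromatic swaps read the same with allyl as with cyclopropyl also stays open.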